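Replacing the 2-methylpyridin-4-yl group of compound 1

The source may report more compounds than this note shows. Statements on the series, on what has been measured and on what is new or still open speak of the compounds shown alone.

Measured so far in a physicochemical assay for lipophilicity; a lower number here means a more polar compound, a higher number a more lipophilic compound

- Compound 1 `CCn1cnc2c(-c3ccc(F)c(Oc4ccnc(C)c4)c3)cnnc21` gives 2.6
- Compound 2 `CCn1cnc2c(-c3ccnc(Oc4ccccc4)c3)cnnc21` gives 2.6

Compound 1 stands level with compound 2 on this scale, with the two values lying within the usual scatter of repeated measurements. The next compound to be measured is compound 3 `CCn1cnc2c(-c3ccc(F)c(Oc4cnc(C#N)nc4)c3)cnnc21` which keeps the rest of compound 1 but carries 2-cyanopyrimidin-5-yl in place of 2-methylpyridin-4-yl on an oxygen on an aromatic ring. Going by the values given here, no pair of measured compounds shows a change of this kind, so the data offer no direct guide. The expectation rests on the structural change alone, and it points to a moderate downward move in this assay that goes beyond the scatter. The expected step is a number 0.50 log units lower from compound 1 to compound 3 (beyond the scatter) in this estimate. Compound 3 is expected at 2.1 (estimated range 1.6 to 2.6).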

Compound 3, distribution coefficient: 2
Estimate against measurement, compound 3: 0.10 log units above, within the range that was stated.
By their numbers in this assay, from the lowest: compound 3; then compounds 1 and 2 (each within the scatter of the next).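

Changing the group on the oxygen on an aromatic ring clearly moves the reading in this assay: replacing 2-methylpyridin-4-yl with 2-cyanopyrimidin-5-yl gives a number 0.60 log units lower from compound 1 to compound 3 (beyond the scatter) while the rest of the molecule stays the same. The swap changes several things at once, with 2 hetero atoms in the six-membered aromatic ring instead of 1, a new triple bond, and 3 hydrogen-bond acceptors instead of 1. Nothing available here accounts for the size of this step.

The compounds shown change these features together, so it remains open how much of the step belongs to the nitrile and how much to the ring. From the compounds shown here alone, how 2-methylpyrimidin-5-yl or 2-aminopyrimidin-5-yl would read on the same oxygen also remains open.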